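The source may report more compounds than this note shows. Statements on the series, on what has been measured and on what is new or still open speak of the compounds shown alone.

Of the compounds shown here, three sharing one core have been measured for their effect on the growth of a leukaemia cell line. Compound 1 `OCC(O)Cn1nc2c(Br)c(Br)c(Br)c(Br)c2n1` carries a short hydroxylated chain, while compound 2 `OC(CCn1nc2c(Br)c(Br)c(Br)c(Br)c2n1)c1ccc(Br)cc1` and compound 3 `OC(CCn1nc2c(Br)c(Br)c(Br)c(Br)c2n1)c1ccccc1` carry a longer chain ending in an aromatic ring. In a functional assay on CCRF-CEM cells (Homo sapiens) for antiproliferative activity, read by MTT assay, with a stated time of 48 h, tested at 100 uM (a higher number here means a weaker effect of the compound at the concentration tested, a lower number a stronger effect), compound 1 gives 1%, compound 2 gives 0% and compound 3 gives 0%. All three numbers sit close together; the step of no change at the digits printed from compound 2 to compound 3 (within the scatter) shows that removing the bromo from the aromatic ring made no difference that the assay can resolve, and compound 3 stands level with compound 2, with compound 1 only a hair above both and still within the scatter.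

Compound 4 `COc1cccc(C(O)CCn2nc3c(Br)c(Br)c(Br)c(Br)c3n2)c1` is the next variation on this aromatic ring: methoxy in place of hydrogen on an aromatic carbon. Among the measured compounds shown here, the only comparable step measured so far is the one from compound 2 to compound 3, which changed nothing beyond the scatter, and no measured compound carries an oxygen-bearing substituent on that ring. The expectation is therefore that compound 4 stays where compound 3 stands, with a number 2 percentage points higher from compound 3 to compound 4 (within the scatter) expected to be no step beyond the scatter. Compound 4 is estimated at 2%, within a range from 0% to 12%.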

Compound 4, a percentage reported as activity, at one concentration (the size of the read-out at that concentration, not a potency): 2%
Compound 4: middle estimate and measured number agree at the digits printed, within the range that was stated.
By their numbers in this assay, from the lowest: compounds 2, 3, 1 and 4 (each within the scatter of the next).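

In this assay, methoxy on an aromatic carbon of the six-membered ring, meta to a large group, gives a number 2 percentage points higher from compound 3 to compound 4 (within the scatter) and so shows that an oxygen-bearing substituent at this position, unlike the bromo and hydrogen compared so far, also leaves the read-out unresolved. Exchanging the whole end group, with 3-methoxyphenyl in place of 4-bromophenyl, gives a number 2 percentage points higher from compound 2 to compound 4 (within the scatter) and so extends this picture: the three ring variants in compounds 2, 3 and 4 cannot be told apart here, even though their substituents sit at different places on the ring. No information is available that would explain this outcome.

All the numbers lie close together at the low end of the scale at a single concentration, so these compounds leave open whether the ring substituents would separate at lower concentrations, where a stronger or weaker effect might be seen at that concentration. Also open, on these data alone, is how the result would change with an amine or a carboxylic acid on the aromatic ring, or with a longer chain between the shared core and that ring.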